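Extending Compound 2 with a Benzamido Group

The source may report more compounds than this note shows. Statements on the series, on what has been measured and on what is new or still open speak of the compounds shown alone.

Compound 1 `O=C1c2ccccc2C(=O)N1CNc1ccc(F)cc1` and compound 2 `CCOc1ccc(NCN2C(=O)c3ccccc3C2=O)cc1` were both measured in an assay on isolated protein for inhibition of ribosomal protein S6 kinase alpha-2 (Homo sapiens), read by fluorescence, with a stated time of 20 min, tested at 10 uM; on this read-out lower numbers stand for less inhibition and higher numbers for more inhibition at the one concentration tested (going by the name of the read-out). Compound 1 gives 56.7% in this assay, while compound 2 gives 100%. Among the measured compounds shown here, the one measured step, a number 43.3 percentage points higher from compound 1 to compound 2 (beyond the scatter), leaves compound 2 standing highest of the two numbers, with compound 1 the nearest and separated from it beyond the scatter.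

Compound 3 `CCOc1ccc(NCN2C(=O)c3ccc(NC(=O)c4ccccc4)cc3C2=O)cc1` differs from compound 2 by benzamido in place of hydrogen on an aromatic carbon. For the measured compounds named here, the single measured step concerns a substituent on the other aromatic ring of the shared core and does not bear on this change. Because compound 2 already gives 100%, the top of the read-out, no rise is possible; the only question is whether inhibition is kept. Compound 3 is expected to stay near the top, an expected step of a number 7 percentage points lower from compound 2 to compound 3 (within the scatter). The estimate for compound 3 is 93%, between 70% and 100%.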

Compound 3, a percentage reported as inhibition, at one concentration (the size of the read-out at that concentration, not a potency): 69.5%
Compound 3: the middle estimate sits 23.5 percentage points above what was measured; measured number outside the range, below it.
By their numbers in this assay, from the lowest: compound 1; then compound 3; then compound 2.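

In this assay benzamido on an aromatic carbon of the fused two-ring system brings a number 30.5 percentage points lower from compound 2 to compound 3 (beyond the scatter) and so shows that this place on the shared core is sensitive to what it carries, which the earlier step, on the other aromatic ring, could not show. The loss is partial, since compound 3 with 69.5% keeps a substantial part of the inhibition at the one concentration tested. Nothing available accounts for this drop.

On these data alone, whether a simple amine or a carboxylic acid at this same place would keep inhibition closer to that of compound 2 remains open. Also open, as far as these compounds go, is whether the loss follows the amide link or the added aromatic ring, which an acetamido group at this place would help to separate.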